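The source may report more compounds than this note shows. Statements on the series, on what has been measured and on what is new or still open speak of the compounds shown alone.

Compound 1 `O=C([C@@H]1CCCN(S(=O)(=O)c2ccc(S(=O)(=O)N3CC[C@@H](O)C3)cc2)C1)N1CCC(F)(F)CC1` carries the lowest number of the three measured here: in a functional assay on BXPC-3 cells (Homo sapiens) for inhibition, read by MTT assay, with a stated time of 7 days (on this read-out lower numbers stand for stronger inhibition and higher numbers for weaker inhibition), compound 1 gives 330 nM, while compound 3 `CCN(CC)S(=O)(=O)c1ccc(S(=O)(=O)N2CCC[C@@H](C(=O)N3CCOCC3)C2)cc1` gives 790 nM and compound 2 `CCN(CC)S(=O)(=O)c1ccc(S(=O)(=O)N2CCC[C@@H](C(=O)N[C@H]3CC[C@H](OC)CC3)C2)cc1` gives 2000 nM. Going by the values given here, the only single-site step measured, a 2.5-fold lower number from compound 2 to compound 3 (0.40 log units; beyond the scatter), sits on the carbonyl carbon and leaves the sulfonyl end untouched, so it does not bear directly on the move to compound 4 `CC(C)S(=O)(=O)c1ccc(S(=O)(=O)N2CCC[C@@H](C(=O)N3CCC(F)(F)CC3)C2)cc1`, which differs from compound 1 by isopropyl in place of 3-hydroxypyrrolidin-1-yl on a sulfonyl sulfur. Among the compounds with values here, no measured pair isolates the group on that sulfonyl sulfur, and the two compounds bearing diethylamino there differ from compound 1 at the carbonyl as well. With no guide, a step of a 1.5-fold higher number from compound 1 to compound 4 (0.18 log units; within the scatter) is expected, giving compound 4 an estimated 500 nM in this assay, within 200 nM to 1500 nM.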

Compound 4, half-maximal inhibitory concentration: 50 nM
Beside the measured number, compound 4's estimate is 10-fold (1.00 log units) above it; measured number below the stated range.
By their numbers in this assay, from the lowest: compound 4; then compound 1; then compound 3; then compound 2.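

In this assay, going by these compounds alone, the group on the sulfonyl sulfur is isolated for the first time: with the carbonyl end held constant, isopropyl in place of 3-hydroxypyrrolidin-1-yl gives a 6.6-fold lower number from compound 1 to compound 4 (0.82 log units; beyond the scatter), beyond the scatter. A ring, a hydroxyl and a defined stereocentre at this place are therefore not required for a low number in this pair. No measurement shown explains the step.

Open, on these data alone, is whether pyrrolidin-1-yl without the hydroxyl, or methyl or tert-butyl on the same sulfur, would track compound 4 or compound 1. Also open, as far as these compounds go, is whether the step carries over to the morpholin-4-yl amide.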